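The source may hold more compounds than are shown below. What is called first, only, known or untested is meant among the compounds shown, and "the series" means these compounds.

In a functional assay on HT-1080 cells (Homo sapiens) for antiproliferative activity, read by sulforhodamine B assay, with a stated time of 48 h (a lower number here means a stronger inhibitor, a higher number a weaker inhibitor), compound 1 `CCCC(=O)Nc1ccc(S(=O)(=O)Oc2ccccc2C(C)C)cc1` gives 950 nM. Compound 2 `CCCC(=O)Nc1ccc(S(=O)(=O)Oc2ccccc2I)cc1` differs from it by iodo in place of isopropyl on an aromatic carbon, and in this assay compound 2 gives 2000 nM, so that change made a step of a 2.1-fold higher number from compound 1 to compound 2 (0.32 log units; beyond the scatter). Compound 3 `CCNC(=O)Nc1ccc(S(=O)(=O)Oc2ccccc2C(C)C)cc1` carries a different core, set apart from the core of compound 1 by ethylamino in place of propyl on a carbonyl carbon, a step of a 3.8-fold lower number from compound 1 to compound 3 (0.58 log units; beyond the scatter); in this assay compound 3 gives 250 nM. Compound 4 `CCNC(=O)Nc1ccc(S(=O)(=O)Oc2ccccc2I)cc1` has not yet been measured; it differs from compound 3 by iodo in place of isopropyl on an aromatic carbon, the same change as from compound 1 to compound 2. The step for compound 4 is expected to be a 2.1-fold higher number from compound 3 to compound 4 (0.32 log units; beyond the scatter), resting on the earlier step of a 2.1-fold higher number from compound 1 to compound 2 (0.32 log units; beyond the scatter) made by this same change. Compound 4 is therefore estimated at 520 nM, between 250 nM and 1100 nM.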

Compound 4, half-maximal inhibitory concentration: 140 nM
Beside the measured number, compound 4's estimate is 3.7-fold (0.57 log units) above it, and the stated range ends above it.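

In this assay, iodo in place of isopropyl on the second core gave a 1.8-fold lower number from compound 3 to compound 4 (0.25 log units; within the scatter), so the step seen on the first core did not carry over: the same change on two cores in this assay, a 2.1-fold higher number (0.32 log units; beyond the scatter) from compound 1 to compound 2 and a 1.8-fold lower number (0.25 log units; within the scatter) from compound 3 to compound 4, 3.8-fold (0.58 log units) apart, beyond the scatter of two such steps. Ethylamino in place of propyl lowered the number on both cores, but with iodo present it gave a 14-fold lower number from compound 2 to compound 4 (1.15 log units; beyond the scatter), so its direction held while its size did not: the same change on two cores in this assay, a 3.8-fold lower number (0.58 log units; beyond the scatter) from compound 1 to compound 3 and a 14-fold lower number (1.15 log units; beyond the scatter) from compound 2 to compound 4, 3.8-fold (0.58 log units) apart, beyond the scatter of two such steps. Across these four compounds, the two changes therefore do not act independently, but this does not show why, or whether the same would hold on any other core.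

The compounds shown leave open how bromo or methoxy on that aromatic carbon would compare. They also leave open whether a longer chain on the nitrogen in place of ethyl would follow the same course.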